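The source may report more compounds than this note shows. Statements on the series, on what has been measured and on what is new or still open speak of the compounds shown alone.

Measured in a functional assay on MCF7 cells (Homo sapiens) for antiproliferative activity, read by MTT assay, with a stated time of 48 h; on this read-out higher numbers stand for weaker inhibition and lower numbers for stronger inhibition:
- compound 1 `CN1CCN(CC(=O)Nc2ccc3ncnc(Nc4cccc(Br)c4)c3c2)CC1`: 10000 nM
- compound 2 `O=C(CN1CCCC1)Nc1ccc2ncnc(Nc3ccc(Br)cc3)c2c1`: > 100000 nM (a limit, not a number)

Compound 2 has only a limit in this assay, > 100000 nM, and no number. Its position on the scale is therefore open on one side, and any comparison with it has to stay loose.

The next compound is compound 3 `CN1CCN(CC(=O)Nc2ccc3ncnc(Nc4ccc(Br)cc4)c3c2)CC1`. It keeps the shared core of compound 2 and changes one group, on a saturated chain carbon bound to a carbonyl carbon: 4-methylpiperazin-1-yl in place of pyrrolidin-1-yl on a saturated chain carbon bound to a carbonyl carbon. In words, 4-methylpiperazin-1-yl takes the place of pyrrolidin-1-yl.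

Within the data shown here, no pair of measured compounds shows this change on its own, so the expectation rests on thin ground. Among the measured compounds shown here, the one guide is compound 1, which also carries 4-methylpiperazin-1-yl and gives a true number, 10000 nM. With that value in mind, the expected step of an at least 3.3-fold lower number from compound 2 to compound 3 (0.52 log units; beyond the scatter) points towards stronger inhibition, though its size is uncertain and the reading may well stay at the limit.

The estimate for compound 3 is 30000 nM, with an expected range from 8000 nM to 100000 nM.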

Compound 3, half-maximal inhibitory concentration: > 100000 nM
Compound 3: only a limit was reported; the forecaster's own chance of this, stated with the estimate: 30%; at least 3.3-fold (0.52 log units) between middle value and limit.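

Compound 3 sits at the same limit as compound 2, so the swap of pyrrolidin-1-yl for 4-methylpiperazin-1-yl on a saturated chain carbon bound to a carbonyl carbon cannot be read as a step in this assay. Among these compounds, the result does give the first readable comparison: with 4-methylpiperazin-1-yl held fixed, 4-bromophenyl in place of 3-bromophenyl on a nitrogen on an aromatic ring gives an at least 10-fold higher number from compound 1 to compound 3 (1.00 log units; beyond the scatter), which means weaker inhibition, and this change of the bromine's place on the phenyl ring is the only step here with a readable size. Any difference between the two 4-bromophenyl compounds stays hidden, and the ceiling of the assay sets how little can be read here: the limit of > 100000 nM in this assay, at which 2 of the 3 values shown sit.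

Still open, going by these compounds, is whether 3-bromophenyl would give a true number with pyrrolidin-1-yl on the chain, which would show whether the effect of the bromine's place holds with another amine. Also open, on these data alone, is what a different amine on the chain, such as morpholin-4-yl, or a different halogen on the phenyl ring, such as chlorine, would do to the reading.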